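Imidazole Amide in Place of Fluorophenyl: Expected Cell Toxicity

The source may hold more compounds than are shown below. What is called first, only, known or untested is meant among the compounds shown, and "the series" means these compounds.

Compound 1 `COc1ccc(-c2cnc(NC(=O)c3ncc[nH]3)n2C)cc1`: in a toxicity assay on THP-1 cells (Homo sapiens) for inhibition (on this read-out lower numbers stand for higher toxicity in this test and higher numbers for lower toxicity in this test), compound 1 gives > 100000 nM, which is a limit of the assay.
Compound 2 `COc1cccc(-c2cnc(NC(=O)c3ccc(F)cc3)n2C)c1`: in this assay compound 2 gives > 100000 nM, also a limit.
Compound 3 `COc1ccc(-c2cnc(NC(=O)c3ccc(F)cc3)n2C)cc1`: in this assay compound 3 gives >= 50000 nM, again a limit.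

Compound 4 `COc1cccc(-c2cnc(NC(=O)c3ncc[nH]3)n2C)c1` is not yet measured. It differs from compound 2 by 1H-imidazol-2-yl in place of 4-fluorophenyl on a carbonyl carbon. The same change was already made from compound 3 to compound 1, (1H-imidazol-2-yl in place of 4-fluorophenyl on a carbonyl carbon), where it produced a step that the two limits leave unreadable from compound 3 to compound 1; that step stays unreadable because the limit of > 100000 nM in this assay, at which 2 of the 3 values shown sit, and the limit of >= 50000 nM in this assay, at which 1 of the 3 values shown sits, cap both ends. The cores of compound 2 and compound 3 differ by 3-methoxyphenyl in place of 4-methoxyphenyl on an aromatic carbon, giving a step that the two limits leave unreadable from compound 2 to compound 3, again unreadable for the same reason. Every measured compound in this assay thus sits at a limit, so none can be ordered against another.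

The expected step in this assay is a step that the limit leaves unreadable from compound 2 to compound 4, resting on a step that the two limits leave unreadable from compound 3 to compound 1 and on compound 2 sitting at the limit of > 100000 nM in this assay, at which 2 of the 3 values shown sit. Compound 4 is therefore estimated at 150000 nM, with a range from 60000 nM to 400000 nM, most likely reported only as a limit.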

Compound 4, half-maximal cytotoxic concentration: > 100000 nM
Compound 4: a limit, no number; the forecaster's own chance of this, stated with the estimate: 85%; the middle value does not contradict the limit.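

In this assay compound 4 gives > 100000 nM, which is a limit of the assay. Within the data shown here, compound 2 also sits at a limit, so no step from compound 2 to compound 4 can be read. The compounds shown leave open at what concentration any of them turns toxic to these cells, and whether 1H-imidazol-2-yl in place of 4-fluorophenyl shifts that concentration.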